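The compounds below may be only part of what the source reports. "The series", "measured", "known", "first", "only" and "open" are said of these compounds alone.

Measured so far in a functional assay on HepG2 cells (Homo sapiens) for cytotoxicity, read by MTT assay, with a stated time of 72 h; a higher number here means a weaker inhibitor, a lower number a stronger inhibitor:
compound 1 `CNC(=O)c1cc(Oc2ccc(NC(=O)c3nn(-c4ccccc4OC(F)(F)F)c(=O)cc3C)cc2F)ccn1` — > 40000 nM
compound 2 `CNC(=O)c1cc(Oc2ccc(NC(=O)c3nn(-c4ccccc4F)c(=O)cc3C)cc2F)ccn1` — > 40000 nM
compound 3 `Cc1cc(=O)n(-c2ccc(Br)cc2F)nc1C(=O)Nc1ccc(Oc2ncnc3ccsc23)cc1` — 10600 nM

Compound 3 gives the only number shown; the other two values are limits, and the limit of > 40000 nM in this assay, at which 2 of the 3 values shown sit, is where they sit. For compound 1 the value is a limit of this assay. For compound 2 the value is likewise a limit. The step from compound 1 to compound 2 is a step that the two limits leave unreadable from compound 1 to compound 2 and concerns a different position, so it gives no readable size.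

Compound 4 `Cc1cc(=O)n(-c2cccc(F)c2)nc1C(=O)Nc1ccc(Oc2ncnc3ccsc23)cc1` differs from compound 3 by 3-fluorophenyl in place of 4-bromo-2-fluorophenyl on an aromatic nitrogen. For the measured compounds named here, no measured step tracks this change. In this assay compound 4 is expected to remain close to compound 3, with an estimated step of a 1.4-fold higher number from compound 3 to compound 4 (0.15 log units; within the scatter) and an estimated value of 15000 nM, range 5000 nM to 40000 nM.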

Compound 4, half-maximal inhibitory concentration: 10200 nM
Compound 4: the middle estimate sits 1.5-fold (0.17 log units) above what was measured; low and high end bracket the measured number.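

In this assay, for the compounds shown here, 3-fluorophenyl in place of 4-bromo-2-fluorophenyl on the aromatic nitrogen gives a 1.0-fold lower number from compound 3 to compound 4 (0.02 log units; within the scatter), the first readable step. Compound 1 and compound 2 both sit at limits, and the step between them cannot be read. No measured evidence here accounts for the two aryl groups reading alike.

Open, going by these compounds, is whether a carboxylic acid or an amine on this phenyl ring, or a longer alkyl chain in its place on the nitrogen, would move the read-out. Also open, on these data alone, is how the same change behaves on the core of compound 1.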